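The compounds below may be only part of what the source reports. "The series", "measured", "known", "first", "only" and "open" are said of these compounds alone.

Going by the values given here, compound 1 `Cc1nc(-c2ccccc2NCC2=NCCN2)co1` is one of only two compounds with a result in a functional assay for activation of Alpha-1D adrenergic receptor (Homo sapiens); a higher number here means that more compound is needed for the effect, a lower number that less compound is needed. In this assay compound 1 gives < 5020 nM, which is a limit of the assay rather than a number, as recorded in the limit of < 5020 nM in this assay, at which 1 of the 2 values shown sits. Compound 2 `FC(F)(F)c1cccnc1-c1ccccc1NCC1=NCCN1` shares the core with compound 1 but carries a different aromatic ring. In this assay compound 2 gives < 100000 nM, again a limit of the assay, as recorded in the limit of < 100000 nM in this assay, at which 1 of the 2 values shown sits. Among the compounds with values here, compound 1 thus stands at a limit, and the only other value shown is a limit as well, so the two cannot be ranked against each other.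

Compound 3 `CCO/N=C(\C)c1ccccc1NCC1=NCCN1` has not yet been measured. Within the data shown here, it differs from compound 1 in one place: a group of 6 heavy atoms (4 carbon, 1 nitrogen, 1 oxygen; no ring) in place of a group of 6 heavy atoms (4 carbon, 1 nitrogen, 1 oxygen; one five-membered aromatic ring with 2 hetero atoms), on an aromatic carbon No step between two measured compounds is known here, so the size of this change cannot be read from the data. With both known values being limits, the expected step in this assay is a step that the limit leaves unreadable from compound 1 to compound 3, a change that is expected to stay within the scatter. Compound 3 is therefore estimated to give 2500 nM in this assay, with an expected range from 400 nM to 10000 nM.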

Compound 3, half-maximal effective concentration: < 5020 nM
Compound 3: no number, only a limit; the forecaster's own chance of this, stated with the estimate: 40%; the middle value is on the limit's open side.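

Compound 1 and compound 3 each give only a limit of the assay and not a number, so no step between them can be read: the limit of < 5020 nM in this assay, at which 2 of the 3 values shown sit.

The compounds shown leave open how much of any of them is needed for the effect in this assay, and whether exchanging the 2-methyl-1,3-oxazol-4-yl group for a group with no ring changes that amount at all.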